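Swapping amino for hydrogen on a fused purine-like core

The compounds below may be only part of what the source reports. "The series", "measured", "known", "first", "only" and "open" are said of these compounds alone.

Compound 1 `Nc1nc(Cl)c2ncn(Cc3ccccc3CCl)c2n1` carries an amino group and a chloro group on its fused two-ring core, with a benzyl arm bearing a chloromethyl substituent. Going by the values given here, in a functional assay on HCT-116 cells (Homo sapiens) for cytotoxicity, read by sulforhodamine B assay, with a stated time of 48 h (a lower number here means a stronger inhibitor of growth, a higher number a weaker inhibitor of growth), compound 1 gives 3980 nM, the highest of the three numbers measured so far. Compound 2 `ClCc1cccc(Cn2cnc3nc(Cl)nc(Cl)c32)c1`, which has two chloro groups on the core and the chloromethyl on a different position of the benzyl ring, gives 750 nM. Compound 3 `ClCc1ccccc1Cn1cnc2nc(Cl)nc(Cl)c21` has two chloro groups on the core and the same benzyl arm as compound 1; in this assay compound 3 gives 1860 nM. Both of those numbers sit below that of compound 1, and the gaps lie beyond the scatter of this kind of measurement.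

Compound 4 `ClCc1ccccc1Cn1cnc2c(Cl)ncnc21` is the unmeasured partner. Compared with compound 1 the change is hydrogen in place of amino on an aromatic carbon. Among the compounds with values here, no directly comparable pair of measured compounds shows what this exact swap does, so the expectation rests on the general picture that compound 1 is the weakest of the three. A step of moderate size, most likely toward a somewhat lower number, is expected as a 1.6-fold lower number from compound 1 to compound 4 (0.20 log units; within the scatter), though it may not exceed the scatter. For compound 4 the estimate is 2500 nM, within a range from 700 nM to 9000 nM.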

Compound 4, concentration for 50% growth inhibition: 1900 nM
The estimate for compound 4 lay 1.3-fold (0.12 log units) above the measured number; the measured number falls inside the stated range.
By their numbers in this assay, from the lowest: compound 2; then compounds 3 and 4 (each within the scatter of the next); then compound 1.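

Going by these compounds alone, this is the first pair in the set that differs in one place only, so the effect of a single change can now be read: in this assay, replacing amino with hydrogen on the aromatic carbon between two ring nitrogen atoms gives a 2.1-fold lower number from compound 1 to compound 4 (0.32 log units; beyond the scatter). The step is modest, but it shows that the amino group is not needed at this position for growth inhibition in these cells, since the compound without it gives the lower number. The data offer no measurement that explains why the number moves with this change.

Only amino and hydrogen are shown on this carbon, so what a methyl group, a hydroxyl group or a dimethylamino group would do there remains open. As far as these compounds go, this pair also keeps the chloro group on the core and the chloromethyl group on the benzyl arm unchanged, so it remains unknown whether the same step would appear with a different group in those places, such as a methoxy group on the core.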